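The source may report more compounds than this note shows. Statements on the series, on what has been measured and on what is new or still open speak of the compounds shown alone.

Cytotoxicity notes on the sulfonyl-bridged nucleoside series. Compound 1 `Cn1cnc2c(ncn2[C@@H]2O[C@H](CO[Si](C)(C)C(C)(C)C)[C@@]3(OS(=O)(=O)C=C3N)[C@H]2O[Si](C)(C)C(C)(C)C)c1=O` reports in a functional assay on MT4 cells (Homo sapiens) for cytotoxicity (a higher number here means that more compound is tolerated, a lower number that less compound is tolerated), only a limit of the assay, > 150000 nM. For the measured compounds named here, compound 2 `Cn1cnc2ncn([C@@H]3O[C@H](CO[Si](C)(C)C(C)(C)C)[C@@]4(OS(=O)(=O)C=C4N)[C@H]3O[Si](C)(C)C(C)(C)C)c2c1=O` is the only member with a number in this assay, 156000 nM. The step that the limit leaves unreadable from compound 1 to compound 2 cannot be sized because of the limit of > 150000 nM in this assay, at which 1 of the 2 values shown sits. Compound 3 `CC(C)(C)[Si](C)(C)OC[C@H]1O[C@@H](n2cnc3c(N)ncnc32)[C@H](O[Si](C)(C)C(C)(C)C)[C@]12OS(=O)(=O)C=C2N` carries the change (a group of 10 heavy atoms (5 carbon, 5 nitrogen; one five-membered aromatic ring with 2 hetero atoms, one six-membered aromatic ring with 2 hetero atoms) in place of a group of 11 heavy atoms (6 carbon, 4 nitrogen, 1 oxygen; one five-membered aromatic ring with 2 hetero atoms, one six-membered aromatic ring with 2 hetero atoms), on a saturated ring carbon). Going by the values given here, no measured step bears on this exchange, and the one recorded step is unreadable, so the expected step from compound 2 to compound 3 is a 1.0-fold lower number from compound 2 to compound 3 (0.02 log units; within the scatter). Compound 3 is therefore estimated at 150000 nM, between 50000 nM and 300000 nM, with a fair chance that only a limit results.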

Compound 3, half-maximal cytotoxic concentration: 13000 nM
Compound 3: middle estimate off by 12-fold (1.06 log units), on the high side; the whole stated range lies above it.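

The group on the saturated ring carbon next to the ring oxygen clearly matters in this assay. The group of 10 heavy atoms, with 1 hydrogen-bond donor, in place of the group of 11 heavy atoms gives a 12-fold lower number from compound 2 to compound 3 (1.08 log units; beyond the scatter). The second comparison, an at least 11-fold lower number from compound 1 to compound 3 (1.06 log units; beyond the scatter), points the same way, but its size is only a bound: the limit of > 150000 nM in this assay, at which 1 of the 3 values shown sits.

The compounds shown leave open whether this drop follows the entering hydrogen-bond donor. A methylamino or dimethylamino group in its place would test that.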